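This account rests on a few compounds, and the source may have more. Where it says the series, first, only, none or still open, it means among the compounds named here.

Measured in an ADME assay on LLC-MK2 cells (Macaca mulatta) for cytotoxicity, read by spectrophotometry and crystal violet staining, with a stated time of 4 days; a lower number here means that less compound is tolerated, a higher number that more compound is tolerated:
- compound 1 `CC(C)n1ncc2c(C(=O)N3CCc4cc(F)ccc43)cc(-c3cccs3)nc21`: > 200000 nM (a limit)
- compound 2 `CC(C)n1ncc2c(C(=O)Nc3ccccn3)cc(C3CC3)nc21`: 25000 nM

Among the compounds with values here, compound 2, at 25000 nM, holds the only actual number so far in this assay. Compound 1 reads > 200000 nM, which is a limit of the assay and not a number.

The next compound to be tested is compound 3 `CC(C)n1ncc2c(C(=O)Nc3ccccn3)cc(-c3ccccc3)nc21`. It keeps everything in compound 2 except one group: phenyl in place of cyclopropyl on an aromatic carbon. In words, this is phenyl in place of cyclopropyl on an aromatic carbon.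

Within the data shown here, no two measured compounds differ in one place alone, so the data give no direct guide to the size of this change. Among the measured compounds shown here, with compound 2 at 25000 nM as the only starting number, a small step towards more compound being tolerated is expected in this assay, and it may not go beyond the usual scatter. The expected change is a 1.4-fold higher number from compound 2 to compound 3 (0.15 log units; within the scatter). For compound 3 the estimated half-maximal cytotoxic concentration is 35000 nM, with an expected range from 12000 nM to 120000 nM.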

Compound 3, half-maximal cytotoxic concentration: 12500 nM
Estimate against measurement, compound 3: 2.8-fold (0.45 log units) above; the range from low to high includes it.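

In this assay, within the data shown here, this is the first comparison in which only one place differs: phenyl in place of cyclopropyl on the aromatic carbon next to the ring nitrogen gives a 2.0-fold lower number from compound 2 to compound 3 (0.30 log units; within the scatter). So, for this pair, a six-membered aromatic ring of 6 heavy atoms can stand where a three-membered non-aromatic ring of 3 heavy atoms stood, with no shift that clears the usual spread of repeat measurements, and the two compounds cannot be ranked on this evidence. Compound 1 cannot join the comparison, since it differs in more than one place and its reading is a limit and not a number: the limit of > 200000 nM in this assay, at which 1 of the 3 values shown sits.

What the compounds shown leave open is whether any group at this position moves the number clearly, for example a small methyl, an amine or a carboxylic acid, none of which resembles the two carbon rings compared here. From the compounds shown here alone, it is also open whether the same exchange of rings would give a similar step when the pyridinyl amide of compounds 2 and 3 is replaced by the amide part of compound 1.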